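The source may report more compounds than this note shows. Statements on the series, on what has been measured and on what is new or still open speak of the compounds shown alone.

For the measured compounds named here, in a functional assay on the whole organism with Mus musculus as the target (on this read-out lower numbers stand for an effect already at smaller amounts and higher numbers for an effect only at larger amounts of compound), compound 1 `NC(=O)/C=C1\CCc2cc(F)c(F)cc21` gives 64 mg/kg and compound 2 `NC(=O)/C=C1\CCc2cc(F)ccc21` gives 56 mg/kg, so compound 1 stands within the scatter of the only other measured value. Compound 3 `NC(=O)/C=C1\CCc2ccc(F)cc21` carries one change from compound 1: hydrogen in place of fluoro on an aromatic carbon, on an aromatic carbon ortho to a fluoro group. The nearest measured change is a 1.1-fold lower number from compound 1 to compound 2 (0.06 log units; within the scatter), where the same exchange at the other fluoro stays within the scatter. That single step is thin support, but no step beyond the scatter is expected in this assay. The estimated change is a 1.1-fold lower number from compound 1 to compound 3 (0.03 log units; within the scatter). Compound 3 is expected at 60 mg/kg, with an estimated range of 30 mg/kg to 120 mg/kg.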

Compound 3, dose for half-maximal effect: 56 mg/kg
Estimate against measurement, compound 3: 1.1-fold (0.03 log units) above, and the stated range covers the measured number.
By their numbers in this assay, from the lowest: compounds 2, 3 and 1 (each within the scatter of the next).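

At the aromatic carbon ortho to a fluoro group, in this assay, hydrogen in place of fluoro gives a 1.1-fold lower number from compound 1 to compound 3 (0.06 log units; within the scatter). The exchange at this position therefore stays within the scatter, as the same exchange at the other fluoro does in a 1.1-fold lower number from compound 1 to compound 2 (0.06 log units; within the scatter), so in the series shown neither single fluoro, taken away alone, moves the number beyond the scatter. Nothing measured here speaks to why this position tolerates the exchange.

Open, going by these compounds, is whether a larger group on this carbon, such as an amine or a methoxy group, would move the number. Also open, on these data alone, is what hydrogen at both fluoro-bearing carbons would give.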